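The compounds below may be only part of what the source reports. "The series", "measured", "known", "first", "only" and "open" are said of these compounds alone.

In a functional assay on HepG2 cells (Homo sapiens) for antiproliferative activity, read by MTT assay, with a stated time of 48 h (on this read-out lower numbers stand for stronger inhibition and higher numbers for weaker inhibition), compound 3 `CCc1cccc(CC)c1-n1nncc1CN1C(=O)C2(C(C#N)=C(N)Oc3c(N)cc4nc5ccccc5nc4c32)c2ccccc21` is the only one of the three measured compounds to yield an actual number, 16500 nM. Compound 1 `Cc1cccc(-n2nncc2CN2C(=O)C3(C(C#N)=C(N)Oc4c(N)cc5nc6ccccc6nc5c43)c3ccccc32)c1` reaches only a limit of the assay, > 50000 nM. Compound 2 `Cc1ccc(C)c(-n2nncc2CN2C(=O)C3(C(C#N)=C(N)Oc4c(N)cc5nc6ccccc6nc5c43)c3ccccc32)c1` likewise stops at a limit, > 50000 nM. The move from compound 1 to compound 2 is therefore a step that the two limits leave unreadable from compound 1 to compound 2, because both values sit at the limit of > 50000 nM in this assay, at which 2 of the 3 values shown sit.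

Compound 4 `N#CC1=C(N)Oc2c(N)cc3nc4ccccc4nc3c2C12C(=O)N(Cc1cnnn1-c1ccc(Cl)cc1Cl)c1ccccc12` has not yet been measured; it differs from compound 3 by 2,4-dichlorophenyl in place of 2,6-diethylphenyl on an aromatic nitrogen. Among the compounds with values here, two measured steps bear on this position, and both lead toward the 2,6-diethylphenyl that compound 4 gives up: an at least 3.0-fold lower number from compound 1 to compound 3 (0.48 log units; beyond the scatter) and an at least 3.0-fold lower number from compound 2 to compound 3 (0.48 log units; beyond the scatter). Each shows that putting the diethyl-bearing phenyl in place of a methyl-bearing phenyl helped at least modestly. Within the data shown here, compound 4 instead carries two chlorines, which no measured compound has, so the known steps speak only to leaving the diethyl group. A modest weakening is expected in this assay, a 2.1-fold higher number from compound 3 to compound 4 (0.33 log units; beyond the scatter), with a fair chance that compound 4 again reaches only the limit. Compound 4 is estimated at 35000 nM, within 8000 nM and 50000 nM.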

Compound 4, half-maximal inhibitory concentration: > 50000 nM
Compound 4: only a limit was reported (the forecaster's own chance of this, stated with the estimate: 45%); middle value at least 1.4-fold (0.15 log units) from the limit.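

Putting 2,4-dichlorophenyl in place of 2,6-diethylphenyl on the aromatic nitrogen gives an at least 3.0-fold higher number from compound 3 to compound 4 (0.48 log units; beyond the scatter) in this assay, so the gain seen with compound 3 does not carry over to this ring with two chlorines. Until now only methyl-bearing phenyl rings had been compared with compound 3, and among the four groups shown, 2,6-diethylphenyl alone gives a real number. The steps linking compound 4 with compound 1 and compound 2 cannot be read, because each of these compounds reports only a limit: the limit of > 50000 nM in this assay, at which 3 of the 4 values shown sit.

The compounds shown cannot separate the effect of the ethyl groups themselves from that of their placement on the ring. A phenyl ring bearing two propyl chains or two methoxy groups would test this further.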